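Compound 4 as an Ethylsulfonyl Counterpart of Compound 2

The compounds below may be only part of what the source reports. "The series", "measured", "known", "first", "only" and "open" are said of these compounds alone.

Of the compounds shown here, three that share one core have been measured in an ADME assay on Caco-2 cells (Homo sapiens) for permeability, in the apical to basolateral direction; a lower number here means that the compound crosses the layer more slowly, a higher number that the compound crosses the layer faster. Compound 2 `Cn1cncc1CN1CC(N(CC2CCN(C(=O)OC(C)(C)C)CC2)S(=O)(=O)c2ccccn2)Cc2cc(C#N)ccc21` gives 15.5 10^-6 cm/s, the highest of the three numbers. Compound 3 `Cn1cncc1CN1CC(N(CC2CCN(C(=O)NC(C)(C)C)CC2)S(=O)(=O)c2ccccn2)Cc2cc(C#N)ccc21` gives 0.6 10^-6 cm/s, and compound 1 `Cn1cncc1CN1CC(N(CC2CCN(S(C)(=O)=O)CC2)S(=O)(=O)c2ccccn2)Cc2cc(C#N)ccc21` gives 0.1 10^-6 cm/s. The two steps that set compound 2 apart are both beyond the scatter: a 26-fold lower number from compound 2 to compound 3 (1.41 log units; beyond the scatter) and, in the other direction, a 160-fold higher number from compound 1 to compound 2 (2.19 log units; beyond the scatter). Compound 4 `CCS(=O)(=O)N1CCC(CN(C2Cc3cc(C#N)ccc3N(Cc3cncn3C)C2)S(=O)(=O)c2ccccn2)CC1` has not yet been measured in this assay. It differs from compound 2 by ethylsulfonyl in place of tert-butoxycarbonyl on an amine nitrogen in a ring. The step that bears most directly on this change is a 160-fold higher number from compound 1 to compound 2 (2.19 log units; beyond the scatter). Compound 1 carries methylsulfonyl at the same place where compound 4 carries ethylsulfonyl. The smaller step of a 6.0-fold higher number from compound 1 to compound 3 (0.78 log units; beyond the scatter) shows that the same position also tolerates a modest shift. A large fall is therefore expected in this assay, a 78-fold lower number from compound 2 to compound 4 (1.89 log units; beyond the scatter). Compound 4 is expected to give about 0.2 10^-6 cm/s, in a range from 0.05 10^-6 cm/s to 1 10^-6 cm/s.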

Compound 4, apparent permeability: 0.1 10^-6 cm/s
The estimate for compound 4 lay 2.0-fold (0.30 log units) above the measured number; measured number inside the range.
By their numbers in this assay, from the lowest: compounds 1 and 4 (each within the scatter of the next); then compound 3; then compound 2.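

In this assay, lengthening methylsulfonyl to ethylsulfonyl on the amine nitrogen in a ring leaves no change at the digits printed from compound 1 to compound 4 (within the scatter), so the added methyl on the saturated chain carbon bound to a sulfonyl sulfur does not register here. The swap of tert-butoxycarbonyl for ethylsulfonyl gives a 160-fold lower number from compound 2 to compound 4 (2.19 log units; beyond the scatter), and the swap of (tert-butyl)carbamoyl for ethylsulfonyl gives a 6.0-fold lower number from compound 3 to compound 4 (0.78 log units; beyond the scatter), so a second sulfonyl group now sits with compound 1, under both compounds that carry a carbonyl at this place. Nothing shown accounts for this gap between the sulfonyl and carbonyl groups.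

The compounds shown leave open whether a tert-butylsulfonyl group would stay with compound 1 and compound 4 or move towards compound 2. They also leave open where a plain acetyl group or a longer chain on the sulfonyl, such as propylsulfonyl, would fall.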